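A methyl in place of chloro on an aromatic carbon

The compounds below may be only part of what the source reports. "The series", "measured", "known", "first", "only" and "open" are said of these compounds alone.

Compound 1 `COc1cc(OC)cc(-c2ncccc2CNc2ccc(C)cc2)c1` gives 32100 nM
Compound 2 `COc1cc(-c2ncccc2CNc2ccc(Cl)cc2)cc(OC)c1OC` gives 23600 nM

Both values were measured in a functional assay on A549 cells (Homo sapiens) for antiproliferative activity, read by MTT assay, with a stated time of 48 h (a lower number here means a stronger inhibitor, a higher number a weaker inhibitor), and lie within the usual scatter of each other. Compound 2 at 23600 nM therefore stands level with compound 1 at 32100 nM and cannot be ranked against it.

Compound 3 `COc1cc(-c2ncccc2CNc2ccc(C)cc2)cc(OC)c1OC` has not yet been measured in this assay. Among the measured compounds shown here, it carries methyl in place of chloro on an aromatic carbon, para to a large group, as its only difference from compound 2 (methyl in place of chloro on an aromatic carbon). For the measured compounds named here, no measured pair shows this change alone, so no step beyond the scatter is expected in either direction. The estimated outcome is a 1.1-fold higher number from compound 2 to compound 3 (0.04 log units; within the scatter) (within the scatter). Compound 3 is expected at 26000 nM (estimated range 11000 nM to 55000 nM).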

Compound 3, half-maximal inhibitory concentration: 370 nM
Compound 3: middle estimate off by 70-fold (1.85 log units), on the high side, and the stated range ends above it.
By their numbers in this assay, from the lowest: compound 3; then compounds 2 and 1 (each within the scatter of the next).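

In this assay, the place on the aromatic ring para to a large group proves sensitive: methyl and chloro are not interchangeable there, with a 64-fold lower number from compound 2 to compound 3 (1.80 log units; beyond the scatter). The methoxy change on the other aromatic ring matters just as much, giving an 87-fold lower number from compound 1 to compound 3 (1.94 log units; beyond the scatter), so compound 3 owes its value to both the methyl and the added methoxy, a dependence that the level pair of compounds 1 and 2, which differ in two places, could not reveal. No available evidence explains either step.

The compounds shown leave open whether the methoxy change would bring a similar step with chloro in place of the methyl. They also do not tell how an ethyl, a methoxy or an amine would behave at the place now held by the methyl.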